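Chalcone analogues: a pyridin-2-yl in place of furan-2-yl

A few compounds are considered here, and "the series" means these few. Any claim that something is new, unique, unknown or untested is made for them only; others in the source may bear on it.

Measured compounds:
- compound 1 `COc1ccc(C(=O)/C=C/c2cccc([N+](=O)[O-])c2)c2c1C=CC(C)(C)O2`: 4090 nM
- compound 2 `COc1ccc(C(=O)/C=C/c2ccco2)c2c1C=CC(C)(C)O2`: > 10000 nM

In a functional assay on SW-620 cells (Homo sapiens) for antiproliferative activity, read by MTT assay, with a stated time of 24 h (on this read-out lower numbers stand for stronger inhibition and higher numbers for weaker inhibition), compound 1 gives 4090 nM. Compound 2 is reported only as a limit, > 10000 nM, so its true number is not known. Among the compounds with values here, the single measured step, an at least 2.4-fold higher number from compound 1 to compound 2 (0.38 log units; beyond the scatter), is therefore itself only a lower bound, resting on (the limit of > 10000 nM in this assay, at which 1 of the 2 values shown sits). Compound 2 sits at the weak end of what the two measured values show.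

Compound 3 `COc1ccc(C(=O)/C=C/c2ccccn2)c2c1C=CC(C)(C)O2` differs from compound 2 by pyridin-2-yl in place of furan-2-yl on a double-bonded chain carbon bound to a double-bonded chain carbon. Within the data shown here, no measured step covers this change, and the one that exists, from compound 1 to compound 2, runs to a limit and gives no direction for it. The expectation for compound 3 is a step of an at least 1.1-fold lower number from compound 2 to compound 3 (0.04 log units; that floor lies within the scatter) in this assay, close to no change beyond the scatter. Compound 3 is estimated at 9000 nM, with a range from 3000 nM to 25000 nM.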

Compound 3, half-maximal inhibitory concentration: 5000 nM
The estimate for compound 3 lay 1.8-fold (0.26 log units) above the measured number; the range from low to high includes it.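

At this place on the chain, pyridin-2-yl gives a measured number in this assay, which furan-2-yl did not, as the > 10000 nM of compound 2 is a limit. As far as these compounds go, the change reads as an at least 2.0-fold lower number from compound 2 to compound 3 (0.30 log units; that floor lies within the scatter), so this is only a floor and the true size of the gap stays unknown: the limit of > 10000 nM in this assay, at which 1 of the 3 values shown sits. Pyridin-2-yl and 3-nitrophenyl cannot be told apart on this read-out, with a 1.2-fold higher number from compound 1 to compound 3 (0.09 log units; within the scatter), so a group without the nitro substituent can stand level with one that carries it.

The compounds shown leave open whether the ring nitrogen of pyridin-2-yl matters, which a plain phenyl at this place would test, and whether pyridin-3-yl or pyridin-4-yl would read the same. They also leave open how a dimethylamino group on that ring would read.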